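A few compounds are considered here, and "the series" means these few. Any claim that something is new, unique, unknown or untested is made for them only; others in the source may bear on it.

In a functional assay on PC-3 cells (Homo sapiens) for cytotoxicity, read by colorimetric assay and MTT assay (on this read-out higher numbers stand for weaker inhibition and lower numbers for stronger inhibition), compound 1 `COc1ccc2cc(-c3ccccc3)c(O)nc2c1` gives 10000 nM, compound 2 `COc1cc(OC)c2cc(-c3ccccc3)c(O)nc2c1` gives 10000 nM and compound 3 `CCN(CC)C(=O)Cn1c(=O)c(-c2ccc(OC)cc2)cc2c(OC)cc(OC)cc21` gives 10000 nM, so compound 3 stands level with both others. Compound 4 `COc1ccc(-c2cc3c(OC)cc(OC)cc3n(CCC#N)c2=O)cc1` differs from compound 3 in one place, with cyanomethyl in place of diethylcarbamoyl on a saturated chain carbon bound to an aromatic nitrogen. Among the compounds with values here, no measured step makes this exchange. Within the data shown here, the only step available, no change at the digits printed from compound 1 to compound 2 (within the scatter), is methoxy in place of hydrogen on an aromatic carbon, so it bears on the question only indirectly. With nothing pointing up or down, the expected result in this assay is no change at the digits printed from compound 3 to compound 4 (within the scatter), with no step beyond the scatter. Compound 4 is estimated at 10000 nM, with an expected range of 4000 nM to 15000 nM.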

Compound 4, half-maximal inhibitory concentration: 10000 nM
Estimate against measurement, compound 4: no gap at the digits printed; the range from low to high includes it.
By their numbers in this assay, from the lowest: compounds 1, 2, 3 and 4 (each within the scatter of the next).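

In this assay, putting cyanomethyl in place of diethylcarbamoyl on a saturated chain carbon bound to an aromatic nitrogen gives no change at the digits printed from compound 3 to compound 4 (within the scatter). Within the data shown here, the earlier step concerned only methoxy on an aromatic carbon, so this is the first reading at this position: a group of 7 heavy atoms gives way to one of 3, and the read-out stays the same. No available evidence explains this result. Still open, from the compounds shown here alone, is whether an amine, a carboxylic acid or a longer chain at this place would shift the value.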